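Nitro to hydroxy in thiosemicarbazones: Vero cell tolerance

The source may report more compounds than this note shows. Statements on the series, on what has been measured and on what is new or still open speak of the compounds shown alone.

Measured so far:
compound 1 `O=[N+]([O-])c1ccccc1/C=N\NC(=S)N(Cc1ccccc1)Cc1ccccc1`: < 155000 nM
compound 2 `Oc1ccccc1/C=N\NC(=S)N(Cc1ccccc1)Cc1ccccc1`: 166000 nM
compound 3 `C=CCN(CC=C)C(=S)N/N=C(/C)c1ccc([N+](=O)[O-])cc1`: < 197000 nM

In an ADME assay on Vero cells (Chlorocebus sabaeus) for cytotoxicity, read by MTT assay, with a stated time of 72 h (a higher number here means that more compound is tolerated, a lower number that less compound is tolerated), compound 1 gives < 155000 nM, which is a limit of the assay. Compound 2 gives 166000 nM. The change hydroxy in place of nitro on an aromatic carbon yields an at least 1.0-fold higher number from compound 1 to compound 2 (0.02 log units; that floor lies within the scatter). Compound 3 gives < 197000 nM, which is a limit. The difference between the core of compound 1 and the core of compound 3 is not broken down here.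

Compound 4 `C=CCN(CC=C)C(=S)N/N=C(/C)c1ccc(O)cc1` is not yet measured and differs from compound 3 by hydroxy in place of nitro on an aromatic carbon. The place is not the same: in compound 2 the hydroxy sits ortho to a large group, in compound 4 para to a large group, so this is the same kind of change, not the same change. For compound 4 a step that the limit leaves unreadable from compound 3 to compound 4 is expected, resting on the earlier at least 1.0-fold higher number from compound 1 to compound 2 (0.02 log units; that floor lies within the scatter) lying within the scatter. Compound 4 is estimated at 170000 nM, expected between 80000 nM and 320000 nM.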

Compound 4, half-maximal cytotoxic concentration: 216000 nM
Beside the measured number, compound 4's estimate is 1.3-fold (0.10 log units) below it; the measured number falls inside the stated range.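

In this assay hydroxy in place of nitro on an aromatic carbon gives an at least 1.0-fold higher number from compound 3 to compound 4 (0.03 log units; that floor lies within the scatter) on the core of compound 3. Compound 3 stands only at a limit (< 197000 nM), so the true size of the step on this core cannot be read. The change therefore carries across the two cores only as a floor, with no sign of a real shift on either one and no way to tell the two steps apart: the same change on two cores in this assay, an at least 1.0-fold higher number (0.02 log units; that floor lies within the scatter) from compound 1 to compound 2 and an at least 1.0-fold higher number (0.03 log units; that floor lies within the scatter) from compound 3 to compound 4; the limit leaves it open whether they differ

From the compounds shown here alone, the effect of the change on either core stays open until the nitro compounds have values rather than limits. Also open, going by these compounds, is how this assay would read an amine or a carboxylic acid in the same place on the aromatic ring.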